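The source may report more compounds than this note shows. Statements on the series, on what has been measured and on what is new or still open speak of the compounds shown alone.

Measured so far:
- compound 1, `CCCNc1nc2c(NC3CCCC3)ncnc2n1[C@@H]1O[C@H](CO)[C@@H](O)[C@H]1O`, gives 97 nM in an assay on cell membranes for binding affinity to Equilibrative nucleoside transporter 1 (Homo sapiens); a lower number here means a stronger inhibitor, a higher number a weaker inhibitor
- compound 2, `CNc1nc2c(SCc3ccccc3)ncnc2n1C1O[C@H](CO)[C@@H](O)[C@H]1O`, gives 28 nM in this assay
- compound 3, `CCNc1nc2c(SCc3ccccc3)ncnc2n1C1O[C@H](CO)[C@@H](O)[C@H]1O`, gives 9.5 nM in this assay

Compound 3 stands lowest of the three numbers. Its nearest neighbour is compound 2, and the step of a 2.9-fold lower number from compound 2 to compound 3 (0.47 log units; beyond the scatter) separates them. Among the measured compounds shown here, compound 1 lies furthest away; its value of 97 nM and that of compound 3 lie apart by more than the scatter, and the two structures differ in more than one place, so no single step is drawn between them.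

Compound 4, `CCCCCCNc1nc2c(SCc3ccccc3)ncnc2n1C1O[C@H](CO)[C@@H](O)[C@H]1O`, has not yet been measured in this assay. It differs from compound 3 by butyl in place of hydrogen on a saturated chain carbon, two bonds along the chain from a nitrogen on an aromatic ring. For the measured compounds named here, only one measured step bears on this: the step from compound 2 to compound 3, which also lengthened the chain on the same nitrogen and gave a modestly lower number. Whether a much longer chain carries that trend further is not shown by the data. A small step downward or none beyond the scatter is therefore expected, and the estimated step is a 1.2-fold lower number from compound 3 to compound 4 (0.07 log units; within the scatter). Compound 4 is estimated at 8 nM, within a range from 2.5 nM to 25 nM.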

Compound 4, inhibition constant: 3.7 nM
Estimate against measurement, compound 4: 2.2-fold (0.33 log units) above, within the range that was stated.
By their numbers in this assay, from the lowest: compound 4; then compound 3; then compound 2; then compound 1.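

On this nitrogen, the gain seen on going from methylamino to ethylamino does not stop at ethyl: changing ethylamino to hexylamino gives a 2.6-fold lower number from compound 3 to compound 4 (0.41 log units; beyond the scatter) in this assay, again beyond the scatter. Over the three compounds that differ only in this chain, the whole span is a 7.6-fold lower number from compound 2 to compound 4 (0.88 log units; beyond the scatter), so each longer chain shown here gives a lower number, and none of the three goes against this. Nothing available explains why the longer chain gives the lower number.

Whether the numbers fall steadily from ethyl to hexyl or mostly over part of that span remains open, as the chains of intermediate length lie outside the compounds shown. So does whether an octyl chain would lower the number further, or whether a chain ending in a hydroxyl or an amine would hold the gain.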